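The compounds below may be only part of what the source reports. "The series", "measured", "known", "first", "only" and "open" are said of these compounds alone.

Measured so far in a physicochemical assay for lipophilicity; on this read-out higher numbers stand for higher lipophilicity and lower numbers for lower lipophilicity:
- compound 1 `O=C(NCc1ccccn1)C1=CCCC1C(=O)N1CCCC1`: 0.3
- compound 2 `O=C(NCc1cccnc1)C1=CCCC1C(=O)N1CCCC1`: 0.4

In this assay, within the data shown here, compound 2 gives 0.4, within the scatter of the only other measured compound, compound 1, at 0.3. The next compound is compound 3 `O=C(NCc1ccncc1)C1=CCCC1C(=O)N1CCCC1`, not yet measured. The change is pyridin-4-yl in place of pyridin-3-yl on a saturated chain carbon bound to an amide-type nitrogen.

Among the measured compounds shown here, one measured step bears on this change, a swap of pyridinyl attachment in the same place. This is a number 0.10 log units higher from compound 1 to compound 2 (within the scatter), with pyridin-3-yl in place of pyridin-2-yl. On that single step, no change beyond the scatter is expected in this assay, and no direction can be claimed with confidence. The estimated step of a number 0.10 log units lower from compound 2 to compound 3 (within the scatter) is expected to remain within the scatter. For compound 3 the expected value is 0.3, with an estimated range of 0 to 0.6.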

Compound 3, partition coefficient: 0.4
The estimate for compound 3 lay 0.10 log units below the measured number, within the range that was stated.
By their numbers in this assay, from the lowest: compounds 1, 2 and 3 (each within the scatter of the next).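

In this assay the swap to pyridin-4-yl on a saturated chain carbon bound to an amide-type nitrogen gives no change at the digits printed from compound 2 to compound 3 (within the scatter) and, measured against pyridin-2-yl at the same place, gives a number 0.10 log units higher from compound 1 to compound 3 (within the scatter) as the second new step. Among these compounds, with pyridin-2-yl, pyridin-3-yl and pyridin-4-yl now all read, moving the point of attachment of the pyridinyl group separates none of compound 1, compound 2 and compound 3 beyond the scatter, where previously only a single such swap could be read. No evidence on the origin of this result is available.

Still open, as far as these compounds go, is how this assay responds when the pyridinyl group itself is replaced at this place, for instance by phenyl, a carboxylic acid or an amine. A longer chain between the amide-type nitrogen and the pyridinyl group also remains untested in the compounds shown.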